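A Methyl Added to the Chain of Compound 2

The source may report more compounds than this note shows. Statements on the series, on what has been measured and on what is new or still open speak of the compounds shown alone.

Measured so far, in a functional assay on the whole organism (strain Swiss) with Mus musculus as the target, in the maximal electroshock model, with a stated time of 1 h, at a dose of 100 mg/kg by the intraperitoneal route; a lower number here means a weaker effect, a higher number a stronger effect of the compound at the dose given:
- compound 1, `COc1cccc(N2CCN(C(=O)C(C)N3C(=O)CCC3=O)CC2)c1`, gives 0%
- compound 2, `CC(C(=O)N1CCN(c2ccccc2)CC1)N1C(=O)CCC1=O`, gives 0%
- compound 3, `CC(C(=O)N1CCN(c2ccccc2C(F)(F)F)CC1)N1C(=O)CCC1=O`, gives 25%

Compound 2 sits level with compound 1 at the bottom of the three numbers; only compound 3 stands apart, with a number 25 percentage points higher from compound 2 to compound 3 (beyond the scatter), a modest rise that comes from a trifluoromethyl in place of hydrogen on an aromatic carbon. The step of no change at the digits printed from compound 1 to compound 2 (within the scatter), hydrogen in place of methoxy on an aromatic carbon, stays within the scatter.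

Compound 4, `CCC(C(=O)N1CCN(c2ccccc2)CC1)N1C(=O)CCC1=O`, differs from compound 2 elsewhere: methyl in place of hydrogen on a saturated chain carbon, two bonds along the chain from an amide-type nitrogen in a ring and a carbonyl carbon. Among the measured compounds shown here, both measured steps alter the aromatic ring, not the chain, so neither bears directly on this change; the data hold no step on the chain at all. What they do show is that a small aromatic change left the read-out flat and a larger one lifted it only modestly, from a starting point of zero.

With nothing in the record to push the number either way, compound 4 is expected to stay close to compound 2, an estimated step of a number 5 percentage points higher from compound 2 to compound 4 (within the scatter). The estimated value for compound 4 in this assay is 5%, within a range of 0% to 25%.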

Compound 4, a percentage reported as activity, at one dose (the size of the read-out at that dose, not a potency): 0%
Estimate against measurement, compound 4: 5 percentage points above; the measured number falls inside the stated range.
By their numbers in this assay, from the lowest: compounds 1, 2 and 4 (each within the scatter of the next); then compound 3.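

In this assay, among the compounds shown here, the first measured step on the chain rather than on the aromatic ring, methyl in place of hydrogen on the saturated chain carbon (methyl to ethyl when read one bond further out), gives no change at the digits printed from compound 2 to compound 4 (within the scatter). Compound 2 already gives 0%, so this read-out can show a gain from the change but no loss, and the added methyl shows no gain of the kind seen on the aromatic ring, where the trifluoromethyl gave a number 25 percentage points higher from compound 2 to compound 3 (beyond the scatter). No measurement shown offers an explanation for the flat result on the chain.

Open, from the compounds shown here alone, is whether a longer chain such as propyl, or an amine or a carboxylic acid on this same carbon, would lift the number above that of compound 2 in this assay. Also open, going by these compounds, is whether the ethyl of compound 4 would keep, lose or add to the rise when it is paired with the trifluoromethyl of compound 3, a combination that would show whether the chain matters once the read-out has moved off its starting point.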